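This account rests on a few compounds, and the source may have more. Where it says the series, first, only, none or still open, it means among the compounds named here.

In a functional assay on HL-60 cells (Homo sapiens) for cytotoxicity, read by WST assay, with a stated time of 48 h (a higher number here means that more compound is needed for the effect, a lower number that less compound is needed), compound 1 (`COc1ccccc1C[C@H]1COC(=O)[C@@H]1Cc1ccc(Cl)c(Cl)c1`) gives 14000 nM, compound 2 (`O=C1OC[C@H](Cc2ccccc2F)[C@H]1Cc1ccc(Cl)c(Cl)c1`) gives 28000 nM and compound 3 (`Cc1cccc(C[C@H]2COC(=O)[C@@H]2Cc2ccc(Cl)c(Cl)c2)c1`) gives 22000 nM. Compound 3 therefore stands level with the other two: a 1.6-fold higher number from compound 1 to compound 3 (0.20 log units; within the scatter) and a 1.3-fold lower number from compound 2 to compound 3 (0.10 log units; within the scatter) both lie within the scatter. Compound 4 (`O=C1OC[C@H](Cc2cccc(F)c2)[C@H]1Cc1ccc(Cl)c(Cl)c1`) differs from compound 3 by fluoro in place of methyl on an aromatic carbon. Going by the values given here, no measured step makes this exact change. The nearest are a 2.0-fold higher number from compound 1 to compound 2 (0.30 log units; within the scatter), fluoro in place of methoxy, and a 1.3-fold lower number from compound 2 to compound 3 (0.10 log units; within the scatter), again within the scatter. No step beyond the scatter is therefore expected in this assay. For compound 4, the estimated step is a 1.1-fold lower number from compound 3 to compound 4 (0.04 log units; within the scatter). Compound 4 is expected at 20000 nM, with an estimated range of 10000 nM to 40000 nM.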

Compound 4, half-maximal effective concentration: 14000 nM
For compound 4 the middle estimate is 1.4-fold (0.15 log units) above the measured one, within the range that was stated.
By their numbers in this assay, from the lowest: compounds 1, 4, 3 and 2 (each within the scatter of the next).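

Fluoro in place of methyl on this aromatic carbon, the first direct exchange at this position, leaves the number within the scatter in this assay (a 1.6-fold lower number from compound 3 to compound 4 (0.20 log units; within the scatter)). The 3-fluorophenyl group also stays within the scatter of the 2-fluorophenyl group (a 2.0-fold lower number from compound 2 to compound 4 (0.30 log units; within the scatter)) and the 2-methoxyphenyl group (no change at the digits printed from compound 1 to compound 4 (within the scatter)), so these four aryl groups do not separate here. No supporting data bear on this result.

Going by these compounds, whether an amine or a carboxylic acid on this ring would give a step beyond the scatter remains open. The same question stands for a longer chain at this position.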